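The source may hold more compounds than are shown below. What is called first, only, known or untested is meant among the compounds shown, and "the series" means these compounds.

Measured in a functional assay on the whole organism (strain Wistar) for inhibition, with Rattus norvegicus as the target, read by paw edema, with stated times of 60 min and 3 h, at a dose of 100 mg/kg by the oral route; a higher number here means more inhibition at the dose given (going by the name of the read-out), a lower number less inhibition:
compound 1, `COc1cc2c(cc1OC)C(CC(=O)O)CC2`: 27.5%
compound 2, `CCNC(=O)CC1CCc2cc(OC)c(OC)cc21`: 26.1%
compound 3, `CCCCNC(=O)CC1CCc2cc(OC)c(OC)cc21`: 27.5%

Compound 1 reads the same as compound 3 at the digits shown; its gap to compound 2 is a number 1.4 percentage points lower from compound 1 to compound 2 (within the scatter). All three numbers sit inside the usual scatter of one another, so no ordering among them is claimed.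

Compound 4, `COc1cc2c(cc1OC)C(CC(=O)NC(C)(C)C)CC2`, has yet to be measured. Against compound 1 the change is (tert-butyl)amino in place of hydroxy on a carbonyl carbon. Going by the values given here, two measured steps bear on it directly, a number 1.4 percentage points lower from compound 1 to compound 2 (within the scatter) and no change at the digits printed from compound 1 to compound 3 (within the scatter), each the replacement of hydroxy on the carbonyl carbon by an alkylamino group, and each within the scatter. The step between the two amides, a number 1.4 percentage points higher from compound 2 to compound 3 (within the scatter), is also within the scatter. Nothing in the series shows the paw edema read-out moving with the group on the amide nitrogen. The level of compound 1 is therefore expected to carry over, and for compound 4 the estimated step is a number 0.5 percentage points lower from compound 1 to compound 4 (within the scatter). For compound 4 the estimate is 27%, with a range from 15% to 40%.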

Compound 4, a percentage reported as inhibition, in the whole organism at one dose (the size of the read-out at that dose, not a potency): 33.3%
The estimate for compound 4 lay 6.3 percentage points below the measured number; low and high end bracket the measured number.
By their numbers in this assay, from the lowest: compounds 2, 1, 3 and 4 (each within the scatter of the next).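

In this assay, (tert-butyl)amino in place of hydroxy on the carbonyl carbon gives a number 5.8 percentage points higher from compound 1 to compound 4 (within the scatter) and so, like the ethylamino and butylamino replacements, stays within the scatter of the acid. On the amide-type nitrogen, tert-butyl in place of butyl gives a number 5.8 percentage points higher from compound 3 to compound 4 (within the scatter) and tert-butyl in place of ethyl gives a number 7.2 percentage points higher from compound 2 to compound 4 (within the scatter), so the three alkyl groups shown at this position cannot be ranked in this assay. No measurement at hand explains these numbers.

Still open, from the compounds shown here alone, is whether a carbonyl substituent of another kind, such as a methyl ester, a piperidine amide or an anilide, would move the paw edema read-out beyond the scatter. Also open, going by these compounds, is whether replacing the methoxy groups of the shared core with hydroxy or chloro would do so.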